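This account rests on a few compounds, and the source may have more. Where it says the series, first, only, none or still open, it means among the compounds named here.

In a functional assay on PC-3 cells (Homo sapiens) for antiproliferative activity, with stated times of 2 days and 4 days (on this read-out higher numbers stand for weaker inhibition and lower numbers for stronger inhibition), compound 3 (`COc1ccccc1/C=C/C(=O)c1cc(Br)ccc1O`) gives 1840 nM, which lies within the scatter of compound 2 (`O=C(/C=C/c1ccccc1O)c1cc(Cl)ccc1O`) at 1520 nM, while compound 1 (`COc1ccc(O)c(C(=O)/C=C/c2ccccc2OC)c1`) gives 7330 nM. Compound 4 (`CC(C)Oc1ccccc1/C=C/C(=O)c1cc(Br)ccc1O`) differs from compound 3 by isopropyl in place of methyl on an oxygen on an aromatic ring, or methoxy to isopropoxy. For the measured compounds named here, the only measured step, a 4.0-fold lower number from compound 1 to compound 3 (0.60 log units; beyond the scatter), is a different change, bromo in place of methoxy on an aromatic carbon, and no measured pair shows a change on this oxygen. It offers no firm direction, so no shift beyond the scatter is expected in this assay. The estimated step is a 1.1-fold higher number from compound 3 to compound 4 (0.04 log units; within the scatter). Compound 4 is expected at 2000 nM, within an estimated range of 800 nM to 5000 nM.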

Compound 4, half-maximal inhibitory concentration: 4160 nM
For compound 4 the middle estimate is 2.1-fold (0.32 log units) below the measured one; measured number inside the range.
By their numbers in this assay, from the lowest: compounds 2 and 3 (each within the scatter of the next); then compounds 4 and 1 (each within the scatter of the next).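

In this assay, for the compounds shown here, the change on this oxygen is not silent: methoxy to isopropoxy gives a 2.3-fold higher number from compound 3 to compound 4 (0.35 log units; beyond the scatter), the first measured change at this position, and so weaker inhibition. Going by these compounds alone, the earlier compounds held no pair that changed this oxygen, so this is the only evidence that the group on it affects the read-out. No available evidence accounts for the shift. With only methyl and isopropyl compared here, the result leaves open how an ethyl group or a longer chain such as butyl on this oxygen would read. It also leaves open how a chain ending in an amine would read there.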